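The source may hold more compounds than are shown below. What is called first, only, known or untested is meant among the compounds shown, and "the series" means these compounds.

Two compounds share an anilino-substituted five-membered core carrying a benzene ring. Compound 1 `O=C(O)c1cccc(-c2csc(Nc3ccccc3)n2)c1` and compound 2 `Cc1noc(-c2cccc(-c3cnc(Nc4ccc(F)cc4)o3)c2)n1` have been tested in an ADME assay on microsomes from liver (Homo sapiens) for metabolic stability, read by LC-MS, using NADPH; a lower number here means that the compound disappears faster, a higher number that the compound lasts longer. In this assay compound 1 gives 1.43 h, and compound 2 gives 0.575 h, the lower of the two numbers, a gap beyond the usual scatter. Compound 3 `CC(=O)Nc1cccc(-c2cnc(Nc3ccc(F)cc3)o2)c1` differs from compound 2 in one place: acetamido in place of 3-methyl-1,2,4-oxadiazol-5-yl on an aromatic carbon. Going by the values given here, no measured pair shows this change, so the direction is uncertain. A small lengthening of half-life, or none beyond the scatter, is expected, as the step of a 1.4-fold higher number from compound 2 to compound 3 (0.14 log units; within the scatter) states. Compound 3 is expected to give 0.8 h, within the range 0.35 h to 1.8 h.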

Compound 3, half-life: 1.91 h
Compound 3: middle estimate off by 2.4-fold (0.38 log units), on the low side, outside the stated range (above it).
By their numbers in this assay, from the lowest: compound 2; then compounds 1 and 3 (each within the scatter of the next).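

In this assay, acetamido in place of 3-methyl-1,2,4-oxadiazol-5-yl on this aromatic carbon gives a 3.3-fold higher number from compound 2 to compound 3 (0.52 log units; beyond the scatter), so the group held here clearly affects how long the compound lasts. This is the first change in one place among these compounds, since compound 1 and compound 2 differ in more than one place. Nothing measured here explains why the half-life lengthens. As far as these compounds go, how an amine or a longer propanamido chain on this carbon would fare remains open, as does whether the same change would act alike on the core of compound 1.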